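Cytotoxicity of a Bromophenyl Amide Expected from Methoxy Analogues

The source may report more compounds than this note shows. Statements on the series, on what has been measured and on what is new or still open speak of the compounds shown alone.

Compound 1 `COc1ccccc1NC(=O)COc1cc(C)nc2ccc(C(F)(F)F)cc12`: > 128000 nM, a limit.
Compound 2 `COc1cccc(NC(=O)COc2cc(C)nc3ccc(OC)cc23)c1`: 43000 nM.
Compound 3 `COc1cc(NC(=O)COc2cc(C)nc3ccc(OC)cc23)cc(OC)c1`: > 131000 nM, a limit.

Among the compounds with values here, in an ADME assay on HepG2 cells (Homo sapiens) for cytotoxicity, read by trypan blue exclusion, with a stated time of 48 h, in the presence of a further agent that is not named here (a lower number here means that less compound is tolerated, a higher number that more compound is tolerated), compound 2 gives 43000 nM, the only true number among the three. The value of compound 1 is a limit. The value of compound 3 is likewise a limit. Compound 4 `COc1ccc2nc(C)cc(OCC(=O)Nc3ccc(Br)cc3)c2c1` differs from compound 2 by 4-bromophenyl in place of 3-methoxyphenyl on an amide-type nitrogen. Within the data shown here, the single measured step, an at least 3.0-fold higher number from compound 2 to compound 3 (0.48 log units; beyond the scatter), touches the same ring but with a different group, so it bears only loosely on this change; no other measured pair differs in one place. The limits the limit of > 128000 nM in this assay, at which 1 of the 3 values shown sits, and the limit of > 131000 nM in this assay, at which 1 of the 3 values shown sits, show where numbers may cease. Compound 4 is therefore expected near 60000 nM, between 25000 nM and 140000 nM. That expectation means a step of a 1.4-fold higher number from compound 2 to compound 4 (0.14 log units; within the scatter), hardly beyond the scatter.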

Compound 4, half-maximal cytotoxic concentration: > 125000 nM
Compound 4 ended at the assay's limit; the forecaster's own chance of this, stated with the estimate: 30%; at least 2.0-fold (0.31 log units) between middle value and limit.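

In this assay, 4-bromophenyl in place of 3-methoxyphenyl on the amide-type nitrogen gives an at least 2.9-fold higher number from compound 2 to compound 4 (0.46 log units; beyond the scatter), so this ring need not carry a methoxy group for the number to rise beyond the scatter. Until now, only the added methoxy of compound 3 had shown such a rise from compound 2. Compound 4 stands at a limit, so the step gives only a lower bound on the change: the limit of > 125000 nM in this assay, at which 1 of the 4 values shown sits.

The compounds shown leave open whether the bromine, its place on the ring or the loss of the methoxy carries the step. They also leave open how an amine or a carboxylic acid on this ring would read in this assay.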